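Replacing the sulfonyl amine of compound 1

The source may report more compounds than this note shows. Statements on the series, on what has been measured and on what is new or still open speak of the compounds shown alone.

Measured so far:
compound 1 `O=C(Nc1cccc(S(=O)(=O)N2CCCC2)c1)c1cccnc1N1CCC2(CC1)CC2`: 5460 nM
compound 2 `CC(C)(C)NS(=O)(=O)c1cccc(NC(=O)c2ncc(NS(C)(=O)=O)nc2N2CCC3(CC2)CC3)n1`: 32 nM

In a functional assay on OVCAR-3 cells (Homo sapiens) for activation, with a stated time of 24 h (on this read-out higher numbers stand for an effect only at larger amounts of compound and lower numbers for an effect already at smaller amounts), compound 1 gives 5460 nM, the highest of the two numbers. Within the data shown here, compound 2 gives 32 nM, lower by a gap beyond the scatter, yet the two structures differ in several places and no single step joins them. Compound 3 `O=C(Nc1cccc(S(=O)(=O)NC2CC2)c1)c1cccnc1N1CCC2(CC1)CC2` differs from compound 1 by cyclopropylamino in place of pyrrolidin-1-yl on a sulfonyl sulfur. Among the measured compounds shown here, no measured pair shows this change, so the expectation rests on compound 1 alone. A small step toward lower numbers, not clearly beyond the scatter, is expected: a 1.8-fold lower number from compound 1 to compound 3 (0.26 log units; within the scatter). Compound 3 is estimated at 3000 nM, within 800 nM to 12000 nM.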

Compound 3, half-maximal effective concentration: 2260 nM
Compound 3: the middle estimate sits 1.3-fold (0.12 log units) above what was measured; low and high end bracket the measured number.
By their numbers in this assay, from the lowest: compound 2; then compound 3; then compound 1.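

Among these compounds, the sulfonyl sulfur accepts a change of its amine with a measurable result: in this assay, cyclopropylamino in place of pyrrolidin-1-yl gives a 2.4-fold lower number from compound 1 to compound 3 (0.38 log units; beyond the scatter) as the only single-place comparison so far. The step is modest but beyond the scatter, and the entering group carries a hydrogen-bond donor that pyrrolidin-1-yl lacks. Among the compounds shown here, no evidence on these compounds ties the step to any feature of either group. Still open, as far as these compounds go, is how other amines on this sulfur, such as dimethylamino or morpholin-4-yl, would compare. From the compounds shown here alone, whether the step carries over to a different core also remains open.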